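This account rests on a few compounds, and the source may have more. Where it says the series, first, only, none or still open, it means among the compounds named here.

Working notes on the series. Compound 1 `Fc1ccc(-c2nc3cc(C(F)(F)F)ccc3[nH]2)cc1` in an ADME assay on MDBK cells (Bos taurus) for cytotoxicity, read by MTT assay, with a stated time of 96 h (on this read-out higher numbers stand for lower toxicity in this test and lower numbers for higher toxicity in this test), gives 19000 nM. Compound 2 `O=C(CN1CCCC1)Nc1ccc(-c2nc3cc(C(F)(F)F)ccc3[nH]2)cc1` gives 15000 nM, and compound 3 `CC(=O)Nc1ccc(-c2nc3cc(C(F)(F)F)ccc3[nH]2)cc1` gives 50000 nM. Compound 2 thus holds the lowest of the three numbers: the gap to compound 1, a 1.3-fold lower number from compound 1 to compound 2 (0.10 log units; within the scatter), is within the scatter, whereas a 3.3-fold higher number from compound 2 to compound 3 (0.52 log units; beyond the scatter) and a 2.6-fold higher number from compound 1 to compound 3 (0.42 log units; beyond the scatter) are beyond it. Compound 4 `O=C(CN1CCCC1)Nc1ccc(-c2nc3ccccc3[nH]2)cc1` differs from compound 2 by hydrogen in place of trifluoromethyl on an aromatic carbon. For the measured compounds named here, all three measured steps change the group that distinguishes compounds 1, 2 and 3 from one another; none touches the trifluoromethyl, so no measured step bears on this change, and no step beyond the scatter is expected. For compound 4 the estimate is 15000 nM, with a range of 7000 nM to 35000 nM. The expected step is no change at the digits printed from compound 2 to compound 4 (within the scatter).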

Compound 4, half-maximal cytotoxic concentration: 70000 nM
Compound 4: middle estimate off by 4.7-fold (0.67 log units), on the low side; measured number outside the range, above it.
By their numbers in this assay, from the lowest: compounds 2 and 1 (each within the scatter of the next); then compounds 3 and 4 (each within the scatter of the next).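

For the compounds shown here, the trifluoromethyl position on the shared core matters in this assay: hydrogen in place of trifluoromethyl on this aromatic carbon gives a 4.7-fold higher number from compound 2 to compound 4 (0.67 log units; beyond the scatter), so lower toxicity in this test, whereas the earlier steps all lay at the other end of the molecule. No measurement shown here accounts for this step.

From the compounds shown here alone, whether a chlorine atom or a methyl group on this carbon would read like hydrogen or like trifluoromethyl remains open. Also open, going by these compounds, is whether the step carries over with fluoro or acetamido in place of the pyrrolidine-bearing amide.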